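A Phenyl Ring Replaces Propyl on the Ether Chain

The source may report more compounds than this note shows. Statements on the series, on what has been measured and on what is new or still open speak of the compounds shown alone.

Compound 1 `CCCCCCOc1ccc2c(Cl)ccnc2c1` gives 2440 nM in a functional assay on HCT-116 cells (Homo sapiens) for cytotoxicity, read by MTT assay, with a stated time of 48 h (a higher number here means a weaker inhibitor, a lower number a stronger inhibitor), the highest of the three numbers in hand. Compound 2 `C=CCOc1ccc2c(NCCCN(C)C)ccnc2c1` gives 2100 nM, which lies within the scatter of compound 1, and compound 3 `CCCCCCOc1ccc2c(NCCN(C)C)ccnc2c1` gives 850 nM. Among the measured compounds shown here, the only single-point step, a 2.9-fold lower number from compound 1 to compound 3 (0.46 log units; beyond the scatter), concerns the group on the aromatic carbon and leaves the ether chain untouched. Compound 4 `Clc1ccnc2cc(OCCCc3ccccc3)ccc12` differs from compound 1 on that chain alone: phenyl in place of propyl on a saturated chain carbon, three bonds along the chain from an oxygen on an aromatic ring. For the measured compounds named here, no measured step bears on this chain, and compounds 2 and 3 differ from each other in two places, so their values show nothing that can be tied to the chain by itself. For compound 4 the change is therefore expected to bring no step beyond the scatter, a 1.2-fold lower number from compound 1 to compound 4 (0.09 log units; within the scatter). Compound 4 is estimated at 2000 nM, with a range from 800 nM to 5000 nM.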

Compound 4, half-maximal inhibitory concentration: 800 nM
Beside the measured number, compound 4's estimate is 2.5-fold (0.40 log units) above it, within the range that was stated.
By their numbers in this assay, from the lowest: compounds 4 and 3 (each within the scatter of the next); then compounds 2 and 1 (each within the scatter of the next).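

Among the compounds shown here, the ether chain, which no earlier step touched, turns out to matter on its own: in this assay, with the chloro group kept, phenyl in place of propyl gives a change beyond the scatter (a 3.1-fold lower number from compound 1 to compound 4 (0.48 log units; beyond the scatter)). For the compounds shown here, this is the first sign that this position of the chain responds to a change. No measurement at hand explains the step.

From the compounds shown here alone, it remains open whether a longer chain without a ring, such as octyl, would give a similar step. Also open, going by these compounds, is how a phenyl ring bearing a methoxy group, or the (2-(dimethylamino)ethyl)amino group paired with this chain, would behave.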